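Three Analogues at the Limit and a Fourth Untested

The source may report more compounds than this note shows. Statements on the series, on what has been measured and on what is new or still open speak of the compounds shown alone.

Compound 1: `COc1cc(-c2nnc(SCC(=O)c3ccc(Cl)cc3)n2N)cc(OC)c1OC`; in a functional assay on HepG2 cells (Homo sapiens) for antiproliferative activity, read by MTT assay, with a stated time of 48 h (on this read-out lower numbers stand for stronger inhibition and higher numbers for weaker inhibition), compound 1 gives > 100000 nM, which is a limit of the assay rather than a number.
Compound 2: `COc1cc(-c2nnc(SCC(=O)Nc3ccccc3C)n2N)cc(OC)c1OC`; in this assay compound 2 gives > 100000 nM, again a limit.
Compound 3: `COc1cccc(NC(=O)CSc2nnc(-c3cc(OC)c(OC)c(OC)c3)n2N)c1`; in this assay compound 3 gives > 100000 nM, also a limit.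

Compound 1 therefore stands only at the limit, as do the two others; none of the three is placed relative to the others. The step that the two limits leave unreadable from compound 1 to compound 2 and the step that the two limits leave unreadable from compound 1 to compound 3 are both unreadable, and so is the step that the two limits leave unreadable from compound 2 to compound 3.

Compound 4 is `COc1cc(-c2nnc(SCC(=O)NCc3ccc(C)cc3)n2N)cc(OC)c1OC`. It differs from compound 1 by (4-methylbenzyl)amino in place of 4-chlorophenyl on a carbonyl carbon. The two measured steps that change the same group on the carbonyl carbon are the ones from compound 1 to compound 2 and to compound 3, and both are left unreadable because the limit of > 100000 nM in this assay, at which 3 of the 3 values shown sit, places every value at the same limit. No direction or size beyond the scatter can be read from them for this assay.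

The expectation for compound 4 is therefore that it, too, most likely returns only a limit, so the estimated step of a number no higher from compound 1 to compound 4 (the limit leaves the size open) means no readable change. For compound 4 the estimate is 100000 nM, with a range from 20000 nM to 300000 nM.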

Compound 4, half-maximal inhibitory concentration: > 100000 nM
Compound 4 was reported as a limit; the forecaster's own chance of this, stated with the estimate: 80%; the middle value lies on the limit itself.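

The steps from compound 1, compound 2 and compound 3 to compound 4 cannot be read, because all four compounds share a single limit rather than numbers that can be compared: the limit of > 100000 nM in this assay, at which 4 of the 4 values shown sit.

The compounds shown leave open whether the groups on the carbonyl carbon differ at all in this assay, and how the four compounds rank.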